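The source may report more compounds than this note shows. Statements on the series, on what has been measured and on what is new or still open speak of the compounds shown alone.

Of the compounds shown here, three built on one shared core have been measured. Compound 3 `COC(=O)N1CCN(C(=O)c2nc(Nc3cc(C4CC4)[nH]n3)c3cc(Cl)ccc3n2)C[C@H]1C` gives 84.6% in an ADME assay on a cell-free system (plasma, Homo sapiens), read by HPLC, with a stated time of 120 min, at 37 degrees C (on this read-out higher numbers stand for a more stable compound and lower numbers for a less stable compound), the highest of the three numbers. Compound 1 `CC(C)COC(=O)N1CCN(C(=O)c2nc(Nc3cc(C4CC4)[nH]n3)c3cc(Cl)ccc3n2)C[C@H]1C` gives 73.7% in this assay, and compound 2 `CC(OC(=O)N1CCN(C(=O)c2nc(Nc3cc(C4CC4)[nH]n3)c3cc(Cl)ccc3n2)C[C@H]1C)OC(=O)C(C)(C)C` gives 49.4% in this assay. Compound 4 `CC(OC(=O)C(C)C)OC(=O)N1CCN(C(=O)c2nc(Nc3cc(C4CC4)[nH]n3)c3cc(Cl)ccc3n2)C[C@H]1C` differs from compound 3 by 1-((isopropylcarbonyl)oxy)ethyl in place of methyl on an oxygen next to a carbonyl group. For the measured compounds named here, two measured steps bear on this change: a number 35.2 percentage points higher from compound 2 to compound 3 (beyond the scatter), and a number 24.3 percentage points lower from compound 1 to compound 2 (beyond the scatter). In both, the compound carrying a 1-(((tert-butyl)carbonyl)oxy)ethyl group on that oxygen has the clearly lower number. The new group in compound 4 is of the same kind, so a large downward step is expected, a number 44.6 percentage points lower from compound 3 to compound 4 (beyond the scatter). Compound 4 is therefore estimated at 40%, in a range from 15% to 65%.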

Compound 4, percent of the compound remaining: 17.4%
For compound 4 the middle estimate is 22.6 percentage points above the measured one; measured number inside the range.
By their numbers in this assay, from the lowest: compound 4; then compound 2; then compound 1; then compound 3.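

In this assay, the 1-((isopropylcarbonyl)oxy)ethyl group on this oxygen gives a number 67.2 percentage points lower from compound 3 to compound 4 (beyond the scatter) and a number 56.3 percentage points lower from compound 1 to compound 4 (beyond the scatter), so the earlier drop is not confined to the tert-butyl version of this kind of group. The outer end of the group also matters: hydrogen in place of one methyl of the tert-butyl gives a number 32 percentage points lower from compound 2 to compound 4 (beyond the scatter). No measurement shown explains this difference. Still open, as far as these compounds go, is how a longer chain or a carboxylic acid at that outer end would read, and whether a plain ethyl on the oxygen would stay as high as methyl and isobutyl.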